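The source may report more compounds than this note shows. Statements on the series, on what has been measured and on what is new or still open speak of the compounds shown alone.

In a functional assay on HCT-116 cells (Homo sapiens) for antiproliferative activity, read by MTT assay, with a stated time of 72 h (a lower number here means a stronger inhibitor, a higher number a weaker inhibitor), compound 1 (`COc1ccc(Nc2ccc3c(c2)S(=O)(=O)C=C3)cc1`) gives 1170 nM, compound 2 (`O=S1(=O)C=Cc2cccc(Nc3ccc(OC(F)(F)F)cc3)c21`) gives 2380 nM, and compound 3 (`O=S1(=O)C=Cc2cccc(Nc3ccc(C(F)(F)F)cc3)c21`) gives 1440 nM. Compound 3 lies within the scatter of both compound 1 and compound 2. Compound 4 (`Cc1ccc(Nc2cccc3c2S(=O)(=O)C=C3)cc1`) has methyl in place of trifluoromethyl on an aromatic carbon. Within the data shown here, one measured step bears on this change: a 1.7-fold lower number from compound 2 to compound 3 (0.22 log units; within the scatter). It also alters a group on an aromatic carbon, with trifluoromethyl in place of trifluoromethoxy, and it stays within the scatter. Among the measured compounds shown here, no measured compound carries methyl at this place, so the evidence is thin, and no shift beyond the scatter is expected in this assay. The expected change is a 1.0-fold higher number from compound 3 to compound 4 (0.02 log units; within the scatter). The estimate for compound 4 is 1500 nM, with an expected range of 600 nM to 3800 nM.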

Compound 4, half-maximal inhibitory concentration: 4000 nM
Beside the measured number, compound 4's estimate is 2.7-fold (0.43 log units) below it; measured number above the stated range.
By their numbers in this assay, from the lowest: compounds 1, 3, 2 and 4 (each within the scatter of the next, the first and the last beyond it).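

Among these compounds, at this place, on an aromatic carbon para to a large group, the change to methyl gives the first step beyond the scatter in this assay (a 2.8-fold higher number from compound 3 to compound 4 (0.44 log units; beyond the scatter)). Methyl in place of trifluoromethoxy, however, stays within the scatter (a 1.7-fold higher number from compound 2 to compound 4 (0.23 log units; within the scatter)), so the replaced group decides whether methyl reads as a real change. No measured evidence accounts for this result. The compounds shown leave open how a chlorine, an amine or a carboxylic acid at this place would read in this assay. They also leave open whether the step from trifluoromethyl to methyl would repeat on the core of compound 1.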